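Thiophen-2-yl in place of 2-(trifluoromethyl)phenyl: compound 4

This account rests on a few compounds, and the source may have more. Where it says the series, first, only, none or still open, it means among the compounds named here.

Compound 1, `CCS[C@@H]1[C@H](SCC)[C@@H](Cn2cc(-c3ccc(OC)cc3)nn2)O[C@H]1n1ccc(=O)[nH]c1=O`, gives 16200 nM in a functional assay on HepG2 cells (Homo sapiens) for cytotoxicity, read by MTT assay, with a stated time of 72 h; on this read-out lower numbers stand for an effect already at smaller amounts and higher numbers for an effect only at larger amounts of compound.
Compound 2, `CCS[C@@H]1[C@H](SCC)[C@@H](Cn2cc(-c3ccccc3C(F)(F)F)nn2)O[C@H]1n1ccc(=O)[nH]c1=O`, gives 30300 nM in this assay.
Compound 3, `CCS[C@@H]1[C@H](SCC)[C@@H](Cn2cc(-c3cccc(C)c3)nn2)O[C@H]1n1ccc(=O)[nH]c1=O`, gives 18300 nM in this assay.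

Among these three numbers compound 2 carries the highest, yet neither neighbour is apart from it beyond the scatter: the step of a 1.9-fold higher number from compound 1 to compound 2 (0.27 log units; within the scatter) and the step of a 1.7-fold lower number from compound 2 to compound 3 (0.22 log units; within the scatter) both stay within the usual spread, as does a 1.1-fold higher number from compound 1 to compound 3 (0.05 log units; within the scatter). The three measured compounds differ only in the aryl group on the shared core, and none of those exchanges moved the read-out in a way one could trust.

Compound 4, `CCS[C@@H]1[C@H](SCC)[C@@H](Cn2cc(-c3cccs3)nn2)O[C@H]1n1ccc(=O)[nH]c1=O`, continues the same kind of exchange: thiophen-2-yl in place of 2-(trifluoromethyl)phenyl on an aromatic carbon. All three measured steps bear on this change, since each swaps one aryl group for another at the same place, and each was small. Within the data shown here, no measured step therefore argues for a shift in this assay beyond the scatter in either direction, and no measured compound carries a five-membered aromatic ring in this position that could point elsewhere.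

For compound 4 the expected value in this assay is therefore 22000 nM, with a range from 9000 nM to 50000 nM. This estimate corresponds to a step of a 1.4-fold lower number from compound 2 to compound 4 (0.14 log units; within the scatter), which is expected to remain within the scatter.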

Compound 4, half-maximal effective concentration: 91800 nM
Compound 4: middle estimate off by 4.2-fold (0.62 log units), on the low side; measured number above the stated range.
By their numbers in this assay, from the lowest: compounds 1, 3 and 2 (each within the scatter of the next); then compound 4.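

In this assay, the aromatic carbon of the five-membered aromatic ring with 3 nitrogen turns out not to be indifferent to the group it carries: the exchanges among the three substituted phenyl groups stayed within the scatter, but thiophen-2-yl gives a step beyond it against each of them, with a 3.0-fold higher number from compound 2 to compound 4 (0.48 log units; beyond the scatter), a 5.0-fold higher number from compound 3 to compound 4 (0.70 log units; beyond the scatter) and a 5.7-fold higher number from compound 1 to compound 4 (0.75 log units; beyond the scatter). All three steps point the same way and are modest in size, so compound 4 stands apart from compounds 1, 2 and 3, needing larger amounts for the effect, while those three remain together within the scatter of one another. Nothing shown gives a measured reason for this separation of compound 4 from the phenyl-bearing compounds.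

The exchange replaces a six-membered carbon ring with a five-membered ring holding sulfur and also removes heavy atoms, and the four compounds cannot separate these changes from one another. As far as these compounds go, a plain phenyl, a furan-2-yl or a pyridin-3-yl at this place would help to separate them, and a group of another kind, such as an aminomethyl or a carboxylic acid, remains open as well.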